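The source may hold more compounds than are shown below. What is called first, only, known or untested is meant among the compounds shown, and "the series" means these compounds.

The study follows a small set of triazine-derived compounds in an assay for inhibition of Pro-cathepsin H (Homo sapiens), read by fluorescence, tested at 50 uM; a lower number here means less inhibition, a higher number more inhibition at the concentration tested (going by the name of the read-out). Compound 1, `Clc1nc(Cl)nc(Nc2ccccc2Br)n1`, gives 4.52% in this assay. Compound 2, `O=c1nc(SCc2ccccc2)nc(SCc2cccc(F)c2)[nH]1`, gives 4.18% in this assay, a number close to that of compound 1 and within the scatter of it, so the two cannot be told apart on these measurements. For the measured compounds named here, compound 3, `O=c1nc(SCc2ccccc2)nc(SCc2ccccc2[N+](=O)[O-])[nH]1`, gives "not determined" (no result reported) in this assay, that is, no result was reported for it, so only two numbers exist, both low and both near each other.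

Compound 4, `O=C(O)CSc1nc(SCc2ccccc2)nc(=O)[nH]1`, has not yet been measured. It differs from compound 2 in one place: carboxy in place of 3-fluorophenyl on a saturated chain carbon bound to a sulfur. The benzyl group on the other sulfur and the shared core remain unchanged.

Going by the values given here, with no measured step of this kind to lean on, and with both known numbers lying low and within the scatter of each other, the step expected from compound 2 to compound 4 is none beyond the scatter, a number 0.8 percentage points higher from compound 2 to compound 4 (within the scatter). Compound 4 is therefore expected to give 5% in this assay, with a range from -3% to 15%, since compound 2 at 4.18% gives the nearest point of reference.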

Compound 4, a percentage reported as inhibition, at one concentration (the size of the read-out at that concentration, not a potency): 6.89%
Compound 4: middle estimate off by 1.9 percentage points, on the low side; the range from low to high includes it.
By their numbers in this assay, from the lowest: compounds 2, 1 and 4 (each within the scatter of the next).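

The first step read at this position, carboxy in place of 3-fluorophenyl on a saturated chain carbon bound to a sulfur, comes in this assay to a number 2.7 percentage points higher from compound 2 to compound 4 (within the scatter), so the two compounds cannot be told apart on these measurements. The change is a large one by the count of atoms, since the six-membered aromatic ring leaves and a group with a hydrogen-bond donor and a double bond enters, and yet it shifts the read-out by no more than the scatter, which shows that at this position, for this pair, an aromatic ring is not required to keep the number where it stands, low as that number is. Nothing given here bears on why the two compounds read alike.

From the compounds shown here alone, what remains open is whether any group at this place can lift the read-out beyond the scatter, for instance an amine, a primary amide or a longer chain carrying the carboxylic acid further from the sulfur. The benzyl group on the other sulfur stays the same in both compounds, so whether a change there, such as a pyridine ring in place of its phenyl, would matter is also unanswered.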